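From compound 2 to compound 4: a side-chain change

The compounds below may be only part of what the source reports. "The series", "measured", "known", "first", "only" and "open" are said of these compounds alone.

Measured compounds in an ADME assay on BJ cells (Homo sapiens) for cytotoxicity, with a stated time of 72 h; a lower number here means that less compound is needed, a higher number that more compound is needed for the effect:
- compound 1 `COc1cc2ncnc(-n3nc(-c4ccc(Cl)cc4)nc3N)c2cc1OC` gives > 50000 nM as a limit
- compound 2 `COc1cc2ncnc(-n3nc(-c4ccccn4)nc3N)c2cc1OCCCN1CC(C)OC(C)C1` gives > 25000 nM as a limit
- compound 3 `COc1cc2ncnc(-n3nc(-c4ccccn4)nc3N)c2cc1OCCCNC(=O)CN1C[C@@H](C)O[C@@H](C)C1` gives > 25000 nM as a limit

Compound 2 has > 25000 nM as a limit and no number. Its place is the limit of > 25000 nM in this assay, at which 2 of the 3 values shown sit, and so no rank can be read. The other reading, (the limit of > 50000 nM in this assay, at which 1 of the 3 values shown sits), belongs to compound 1 and is also only a limit.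

Compound 4 `COc1cc2ncnc(-n3nc(-c4ccccn4)nc3N)c2cc1OCCNC(=O)OC(C)(C)C` is not yet measured. The change is (tert-butoxycarbonyl)amino in place of (2,6-dimethylmorpholin-4-yl)methyl on a saturated chain carbon, two bonds along the chain from an oxygen on an aromatic ring and, cut one bond further out, reads 3-(2,6-dimethylmorpholin-4-yl)propoxy to 2-((tert-butoxycarbonyl)amino)ethoxy.

Among the compounds with values here, the one measured step on this side chain is a step that the two limits leave unreadable from compound 2 to compound 3 and no size can be taken from it. With both of its ends at limits, no step beyond the scatter is expected in this assay and no direction can be given. The estimated step is a step that the limit leaves unreadable from compound 2 to compound 4 and it rests on limits alone. Compound 4 is expected at 30000 nM within an estimated range from 10000 nM to 50000 nM and may well report only a limit.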

Compound 4, half-maximal effective concentration: > 15000 nM
Compound 4: no number, only a limit; the forecaster's own chance of this, stated with the estimate: 70%; the middle value lies beyond the limit too.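

In this assay compound 4 gives > 15000 nM, which is a limit and not a number. Within the data shown here, compound 2 also gives only a limit, so no step from compound 2 to compound 4 can be read. The compounds shown leave open what actual values these side chains would have in this assay.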